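The compounds below may be only part of what the source reports. "The series", "measured", "known", "first", "only" and "open" are said of these compounds alone.

Measured in a functional assay on A2780 cells (Homo sapiens) for cytotoxicity, read by MTT assay, with a stated time of 48 h; on this read-out lower numbers stand for stronger inhibition and higher numbers for weaker inhibition:
- compound 1 `CCn1cc(-c2nc3ccccc3o2)c(=O)c2cc(F)c(N3CCN(C)CC3)cc21`: 700 nM
- compound 2 `CCn1cc(-c2nc3ccccc3o2)c(=O)c2cc(F)c(N3CCNCC3)nc21`: 15300 nM
- compound 3 `CCn1cc(-c2nc3ccc([N+](=O)[O-])cc3o2)c(=O)c2cc(F)c(N3CCNCC3)nc21`: "not determined" (no result reported)

Only two of these compounds carry a number, and compound 2, at 15300 nM, has the higher of the two. Compound 1 stands lower at 700 nM, a gap beyond the usual scatter. These two compounds differ in more than one place, so the gap cannot be assigned to any single change. Compound 3 gives no number to compare.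

The next compound to be measured is compound 4 `CCn1cc(-c2nc3ccc(N)cc3[nH]2)c(=O)c2cc(F)c(N3CCNCC3)nc21`. Relative to compound 2, the change is a group of 10 heavy atoms (7 carbon, 3 nitrogen; one five-membered aromatic ring with 2 hetero atoms, one six-membered aromatic ring of carbon only) in place of a group of 9 heavy atoms (7 carbon, 1 nitrogen, 1 oxygen; one five-membered aromatic ring with 2 hetero atoms, one six-membered aromatic ring of carbon only), on an aromatic carbon. The five-membered and six-membered aromatic rings are kept, while the entering group has hydrogen-bond donors that the leaving 1,3-benzoxazol-2-yl lacks.

Among the measured compounds shown here, no measured step isolates a change at this place, so the expectation is weakly anchored. For the measured compounds named here, compound 1 at 700 nM shows only that lower numbers occur. The estimated 1.9-fold lower number from compound 2 to compound 4 (0.28 log units; within the scatter) is small, toward a lower number, and is expected to stay within the usual scatter. For compound 4 the estimated value in this assay is 8000 nM, with an expected range of 2000 nM to 28000 nM.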

Compound 4, half-maximal inhibitory concentration: 42300 nM
Compound 4: the middle estimate sits 5.3-fold (0.72 log units) below what was measured; the whole stated range lies below it.
By their numbers in this assay, from the lowest: compound 1; then compound 2; then compound 4.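

In this assay, among the compounds shown here, the swap of the 1,3-benzoxazol-2-yl for the entering group on this aromatic carbon of the six-membered aromatic ring with 1 nitrogen gives a 2.8-fold higher number from compound 2 to compound 4 (0.44 log units; beyond the scatter), the first step that isolates a change at one place. The number at this position therefore responds to the group's make-up even though the five-membered and six-membered aromatic rings are kept, and here the entering group's hydrogen-bond donors go with weaker inhibition, a reading that rests on this single pair. No measured evidence accounts for the step.

The step cannot separate the exchange of ring oxygen for ring nitrogen from the added amine on the six-membered ring, so a version of the entering group without that amine would be needed to assign the shift. The compounds shown also leave open whether another group at this carbon, such as a carboxylic acid or a simple amide, would give a number lower than that of compound 2.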